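Adding a dimethylamino group to a chalcone amine

This account rests on a few compounds, and the source may have more. Where it says the series, first, only, none or still open, it means among the compounds named here.

Compound 1 `CCN(CC)CCCOc1ccc(C(=O)/C=C/c2ccc(N(C)C)cc2)c(O)c1`: 4100 nM
Compound 2 `CCN(CCCOc1ccc(C(=O)/C=C/c2ccccc2)c(O)c1)Cc1ccccc1N(C)C`: 800 nM

In an assay on isolated protein for inhibition of Amine oxidase [flavin-containing] B (Homo sapiens) (on this read-out lower numbers stand for stronger inhibition and higher numbers for weaker inhibition), compound 2 gives the lower of the two numbers, and compound 1 sits higher by a gap that is beyond the usual scatter. Compound 3 `CCN(CCCOc1ccc(C(=O)/C=C/c2ccc(N(C)C)cc2)c(O)c1)Cc1ccccc1N(C)C` differs from compound 2 by a single change: dimethylamino in place of hydrogen on an aromatic carbon. Going by the values given here, no measured pair shows this change on its own. Compound 1 carries the same dimethylamino group but also a different amine side chain, so it offers only a loose hint. For compound 3 the step of a 1.6-fold higher number from compound 2 to compound 3 (0.21 log units; within the scatter) is expected to be modest, leaning toward a somewhat higher number. Compound 3 is estimated at 1300 nM, within a range from 400 nM to 4500 nM.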

Compound 3, half-maximal inhibitory concentration: 3200 nM
Estimate against measurement, compound 3: 2.5-fold (0.39 log units) below, and the stated range covers the measured number.
By their numbers in this assay, from the lowest: compound 2; then compounds 3 and 1 (each within the scatter of the next).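

In this assay the step of a 4.0-fold higher number from compound 2 to compound 3 (0.60 log units; beyond the scatter) shows that turning phenyl into 4-(dimethylamino)phenyl clearly weakens inhibition when the 2-(dimethylamino)phenyl side chain is present. With 4-(dimethylamino)phenyl in place, swapping that side chain's methyl-ended counterpart gives a 1.3-fold lower number from compound 1 to compound 3 (0.11 log units; within the scatter) and stays within the scatter, so the amine change has no clear effect in this setting. Nothing measured here explains either result. From the compounds shown here alone, whether a smaller group at this spot, such as methoxy or a fluorine atom, would also weaken inhibition remains open.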